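The source may hold more compounds than are shown below. What is called first, only, known or untested is meant among the compounds shown, and "the series" means these compounds.

In a functional assay on HL-60 cells (Homo sapiens) for cytotoxicity, read by ELISA, with a stated time of 2 days (a lower number here means a stronger inhibitor, a higher number a weaker inhibitor), compound 1 (`Oc1ccccc1-c1cc(-c2ccccc2)cc(-c2ccccc2O)n1`) gives 22400 nM while compound 2 (`Oc1cccc(-c2cc(-c3ccccc3)cc(-c3ccccc3)n2)c1`) gives 11500 nM and compound 3 (`Oc1cccc(-c2cc(-c3ccccc3)cc(-c3cccs3)n2)c1`) gives 14100 nM on the same read-out. Compound 3 lies within the scatter of both other compounds, so no ranking around it can be drawn. Compound 4 (`Oc1cccc(-c2cc(-c3ccccc3)cc(-c3ccsc3)n2)c1`) differs from compound 3 (thiophen-3-yl in place of thiophen-2-yl on an aromatic carbon) with thiophen-3-yl in place of thiophen-2-yl on an aromatic carbon next to the ring nitrogen. Going by the values given here, the only measured step at this place (a 1.2-fold higher number from compound 2 to compound 3 (0.09 log units; within the scatter)) is thiophen-2-yl in place of phenyl and stays within the scatter, so no step beyond the scatter is expected in this assay for this swap. The estimated change is a 1.0-fold lower number from compound 3 to compound 4 (0.02 log units; within the scatter) and is expected to stay inside the scatter. For compound 4 the estimated value is 13500 nM with an expected range from 7000 nM to 25000 nM in this series.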

Compound 4, half-maximal inhibitory concentration: 10300 nM
The estimate for compound 4 lay 1.3-fold (0.12 log units) above the measured number; low and high end bracket the measured number.
By their numbers in this assay, from the lowest: compounds 4, 2, 3 and 1 (each within the scatter of the next, the first and the last beyond it).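

In this assay, the two thiophene attachments can now be compared directly: thiophen-3-yl in place of thiophen-2-yl on the aromatic carbon next to the ring nitrogen gives (a 1.4-fold lower number from compound 3 to compound 4 (0.14 log units; within the scatter)), and thiophen-3-yl in place of phenyl gives (a 1.1-fold lower number from compound 2 to compound 4 (0.05 log units; within the scatter)). Neither the attachment point of the thiophene nor the swap from phenyl separates these compounds beyond the scatter. No supporting data bear on this result. 

Still open, as far as these compounds go, is whether an amine, a carboxylic acid or a longer alkyl chain on this carbon would give a step beyond the scatter.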